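The source may hold more compounds than are shown below. What is called first, only, known or untested is meant among the compounds shown, and "the series" means these compounds.

Compound 1, `Cn1c(-c2ccccc2C(F)(F)F)nnc1C12CCC(CCS(C)(=O)=O)(CC1)CC2`, in an assay on CHO-K1 cells for inhibition of 11-beta-hydroxysteroid dehydrogenase type 2 (Mus musculus), read by scintillation proximity assay (on this read-out lower numbers stand for stronger inhibition and higher numbers for weaker inhibition), gives > 4000 nM, which is a limit of the assay.
Compound 2, `Cn1c(-c2ccccc2C(F)(F)F)nnc1C12CCC(CCCC(C)(F)F)(CC1)CC2`, in this assay gives > 4000 nM, again a limit rather than a number.

Compound 2 therefore stands only at a limit on the numbers shown, because the limit of > 4000 nM in this assay, at which 2 of the 2 values shown sit, covers both values. The change to compound 3, `CCCCCC12CCC(c3nnc(-c4ccccc4C(F)(F)F)n3C)(CC1)CC2`, is ethyl in place of 1,1-difluoroethyl on a saturated chain carbon, three bonds along the chain from a saturated ring carbon. Within the data shown here, the only measured step, a step that the two limits leave unreadable from compound 1 to compound 2, is itself unreadable, so it gives no size to lean on. Compound 3 is expected to stay near the same limit, a step that the limit leaves unreadable from compound 2 to compound 3, with an estimated 6000 nM, ranging from 1500 nM to 25000 nM.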

Compound 3, half-maximal inhibitory concentration: > 4000 nM
Compound 3: no number, only a limit; the forecaster's own chance of this, stated with the estimate: 75%; the middle value lies beyond the limit too.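

Compound 3 gives > 4000 nM in this assay, which is a limit and not a number. The steps from compound 1 and from compound 2 to compound 3 cannot be read, because all three compounds stop at one limit: the limit of > 4000 nM in this assay, at which 3 of the 3 values shown sit.

Going by these compounds, how strongly compound 1, compound 2 and compound 3 actually inhibit, and whether their side chains make any difference, stays open.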